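A Bromo for Chloro Swap at the Assay Limit

The source may report more compounds than this note shows. Statements on the series, on what has been measured and on what is new or still open speak of the compounds shown alone.

In a functional assay on MCF7 cells (Homo sapiens) for inhibition, read by sulforhodamine B assay, with a stated time of 48 h (a lower number here means a stronger inhibitor of growth, a higher number a weaker inhibitor of growth), compound 1 (`CCOC(=O)c1nn(-c2ccccc2)c(-c2ccc(Br)cc2)c1CNC(C)(C)C`) gives 74200 nM; > 509000 nM (2 entries). Compound 2 (`CC(C)(C)NCc1c(C(=O)O)nn(-c2ccccc2)c1-c1ccc(Cl)cc1`) stands at > 652000 nM as a limit of the assay and not a number. Compound 3 (`CC(C)(C)NCc1c(C(=O)O)nn(-c2ccccc2)c1-c1ccc(Br)cc1`) carries bromo in place of chloro on an aromatic carbon. Going by the values given here, no measured pair shows this swap, so the expectation rests on the limit of compound 2 (> 652000 nM) alone. No step beyond the scatter is expected in this assay and the estimated step (an at least 1.0-fold lower number from compound 2 to compound 3 (0.03 log units; that floor lies within the scatter)) is small. For compound 3 the estimated value is 600000 nM with a range from 250000 nM to 900000 nM around it.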

Compound 3, concentration for 50% growth inhibition: 293000 nM
Beside the measured number, compound 3's estimate is 2.0-fold (0.31 log units) above it; measured number inside the range.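

In this assay, the change from 4-chlorophenyl to 4-bromophenyl gives an at least 2.2-fold lower number from compound 2 to compound 3 (0.34 log units; beyond the scatter). This shows that the number can respond to a single halogen swap at this place on the aromatic ring, even in a weak compound. Only a floor for the step can be read, because compound 2 stands at a limit of the assay and not at a number: the limit of > 652000 nM in this assay, at which 1 of the 3 values shown sits.

As far as these compounds go, whether a fluoro or a methoxy group at this place would move the number further stays open. Also open, from the compounds shown here alone, is whether the same swap would give a similar step with the ethyl ester of compound 1 in place of the carboxylic acid.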